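Butyl in place of butoxycarbonyl on the carbamate aryl ring

The compounds below may be only part of what the source reports. "The series", "measured", "known", "first", "only" and "open" are said of these compounds alone.

Measured so far in a functional assay on RAW264.7 cells (Mus musculus) for inhibition, with a stated time of 30 min; a lower number here means a stronger inhibitor, a higher number a weaker inhibitor:
compound 1 `C=C1C(=O)OC[C@H]1CCOC(=O)Nc1ccc(C(=O)OCCCC)cc1` gives 430 nM
compound 2 `C=C1C(=O)OC[C@@H]1CCOC(=O)Nc1ccc(I)cc1` gives 790 nM
compound 3 `C=C1C(=O)OC[C@@H]1CCOC(=O)Nc1ccccc1F` gives 690 nM

Compound 1 stands at the low end of these three numbers, yet its gaps to compound 3 and to compound 2 both lie within the usual scatter, so the three cannot be separated on this evidence. Compound 4 `C=C1C(=O)OC[C@H]1CCOC(=O)Nc1ccc(CCCC)cc1` has not yet been measured. It differs from compound 1 in one place: butyl in place of butoxycarbonyl on an aromatic carbon. Going by the values given here, no measured pair shows such a step, and the three values give no sign of how a change at this aromatic carbon moves the number. A step of no more than the scatter, in either direction, is therefore expected in this assay. Compound 4 is accordingly estimated at 600 nM, within a range from 200 nM to 1800 nM, which corresponds to an expected step of a 1.4-fold higher number from compound 1 to compound 4 (0.14 log units; within the scatter).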

Compound 4, half-maximal inhibitory concentration: 620 nM
Beside the measured number, compound 4's estimate is 1.0-fold (0.01 log units) below it; measured number inside the range.
By their numbers in this assay, from the lowest: compounds 1, 4, 3 and 2 (each within the scatter of the next).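

In this assay, the change at this aromatic carbon gives a 1.4-fold higher number from compound 1 to compound 4 (0.16 log units; within the scatter), the first step read at this position. A butyl group, with fewer heavy atoms and no hydrogen-bond acceptors, therefore cannot be told apart here from the butoxycarbonyl group it replaces. Nothing available accounts for this result.

The compounds shown leave open whether a carboxylic acid, an amine or a longer chain at this aromatic carbon would move the number beyond the scatter. They also leave open whether a butyl group would behave the same way elsewhere on the ring.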